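Changing One Side Group in a Growth Inhibition Series

The compounds below may be only part of what the source reports. "The series", "measured", "known", "first", "only" and "open" are said of these compounds alone.

Of the compounds shown here, two sharing one core have been measured so far. In a functional assay on RPMI-8226 cells (Homo sapiens) for inhibition (a higher number here means a weaker inhibitor of growth, a lower number a stronger inhibitor of growth), compound 1 (`C=C1C(=O)O[C@H]2[C@H]1CC/C(COC(=O)N1CCC(F)(F)CC1)=C\CC[C@@]1(C)O[C@@H]21`) gives 1980 nM and compound 2 (`C=C1C(=O)O[C@H]2[C@H]1CC/C(COC(=O)NCCN1CCCC1)=C\CC[C@@]1(C)O[C@@H]21`) gives 8710 nM, which makes compound 2 the weaker growth inhibitor of the pair, by a margin beyond the usual scatter.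

Compound 3 (`C=C1C(=O)O[C@H]2[C@H]1CC/C(COC(=O)Nc1n[nH]c(SC)n1)=C\CC[C@@]1(C)O[C@@H]21`) carries 5-(methylsulfanyl)-1H-1,2,4-triazol-3-yl in place of 2-(pyrrolidin-1-yl)ethyl on an amide-type nitrogen. The core stays the same.

Within the data shown here, only one measured step bears on this change. It also replaces what sits on the carbonyl carbon, and it is modest: a 4.4-fold higher number from compound 1 to compound 2 (0.64 log units; beyond the scatter). Among the measured compounds shown here, no measured compound carries a triazole, so this step gives only a rough scale. With compound 2 at 8710 nM as the higher of just two values, a new group is more likely to give a lower number than a higher one.

The expected change in this assay is therefore modest and downward, estimated as a 3.5-fold lower number from compound 2 to compound 3 (0.54 log units; beyond the scatter), with real uncertainty. Compound 3 is estimated at 2500 nM, with an expected range from 600 nM to 8000 nM as the likely span.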

Compound 3, concentration for 50% growth inhibition: 2570 nM
Beside the measured number, compound 3's estimate is 1.0-fold (0.01 log units) below it; measured number inside the range.
By their numbers in this assay, from the lowest: compounds 1 and 3 (each within the scatter of the next); then compound 2.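

In this assay, replacing 2-(pyrrolidin-1-yl)ethyl with 5-(methylsulfanyl)-1H-1,2,4-triazol-3-yl on the amide-type nitrogen gives a 3.4-fold lower number from compound 2 to compound 3 (0.53 log units; beyond the scatter), so this position responds to the choice of group even though both groups hold 7 heavy atoms. Measured against the 4,4-difluoropiperidin-1-yl on the carbonyl carbon, the (5-(methylsulfanyl)-1H-1,2,4-triazol-3-yl)amino group gives a 1.3-fold higher number from compound 1 to compound 3 (0.11 log units; within the scatter), so two quite different groups read alike here, one keeping the amide hydrogen and the other lacking it. Nothing at hand explains why these numbers fall as they do.

The compounds shown leave open whether the step from compound 2 belongs to the triazole ring or to its methylsulfanyl, a question that a plain 1H-1,2,4-triazol-3-yl on the amide-type nitrogen would help to settle. Also open, going by these compounds, is whether the number of compound 2 reflects its pyrrolidine ring or its ethyl chain, which a simple ethyl group on that nitrogen would help to separate.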